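Iodo for 3-Chlorophenyl in a Dopamine Transporter Series

The source may report more compounds than this note shows. Statements on the series, on what has been measured and on what is new or still open speak of the compounds shown alone.

Compound 1: `COc1cccc(-c2ccc3c(c2)COC3(CCCN(C)C)c2ccc(F)cc2)c1` — "not determined" (no result reported).
Compound 2: `CN(C)CCCC1(c2ccc(F)cc2)OCc2cc(-c3cccc(Cl)c3)ccc21` — 1390 nM.

Within the data shown here, in an assay on Caudate-putamen for displacement of a labelled ligand from sodium-dependent dopamine transporter (Rattus norvegicus), read by scintillation counting (on this read-out lower numbers stand for stronger inhibition and higher numbers for weaker inhibition), compound 2 gives 1390 nM, and this is the only number available, since compound 1 was not measured there. Compound 2 therefore stands alone, with no neighbour to rank it against. Compound 3 is `CN(C)CCCC1(c2ccc(F)cc2)OCc2cc(I)ccc21`, not yet measured. The change from compound 2 to compound 3 is iodo in place of 3-chlorophenyl on an aromatic carbon. Among the measured compounds shown here, no measured pair shows what such a change does in this setting, so the size of the step is open. A moderate shift toward stronger inhibition is expected, though the step from compound 2 to compound 3 may well stay within scatter, estimated at a 2.0-fold lower number from compound 2 to compound 3 (0.30 log units; within the scatter). Compound 3 is expected to give about 700 nM, with a range of 200 nM to 3000 nM.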

Compound 3, inhibition constant: 1350 nM
Beside the measured number, compound 3's estimate is 1.9-fold (0.29 log units) below it, within the range that was stated.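

In this assay the exchange of 3-chlorophenyl for iodo on this aromatic carbon gives a 1.0-fold lower number from compound 2 to compound 3 (0.01 log units; within the scatter) and so leaves compound 2 and compound 3 indistinguishable. The position therefore tolerates two very different groups on this read-out, one of 7 heavy atoms with a six-membered aromatic ring and one of a single iodine atom, and the aromatic ring is not needed to reach this level of inhibition. No accompanying measurement bears on this result.

Going by these compounds, whether a hydrogen, a fluoro group, an amine or a carboxylic acid on the same carbon would also match these two compounds stays open. So does whether a phenyl ring with another substituent, such as a nitrile, would read differently in this assay at this position.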